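From Isobutyl to Sec-Butyl on an Amine Nitrogen

A few compounds are considered here, and "the series" means these few. Any claim that something is new, unique, unknown or untested is made for them only; others in the source may bear on it.

In a functional assay on HT-29 cells (Homo sapiens) for inhibition, read by sulforhodamine B assay, with a stated time of 72 h (on this read-out higher numbers stand for weaker inhibition and lower numbers for stronger inhibition), compound 1 (`C=CCNC(=C\C(=O)/C=C/c1ccc(O)c(OC)c1)/C=C/c1ccc(O)c(OC)c1`) gives 24600 nM and compound 2 (`CC(C)CNC(=C\C(=O)/C=C/c1ccc(O)cc1)/C=C/c1ccc(O)cc1`) gives 22500 nM. These two values lie within the usual scatter of each other, so compound 2 cannot be ranked against compound 1. For compound 3 (`COc1cc(/C=C/C(=O)CC(=O)/C=C/c2ccc(OC(C)=O)c(OC)c2)ccc1OC(C)=O`) the result is a limit of the assay, > 25000 nM. Compound 4 (`CCC(C)NC(=C\C(=O)/C=C/c1ccc(O)cc1)/C=C/c1ccc(O)cc1`) has sec-butyl in place of isobutyl on an amine nitrogen. Among the compounds with values here, no measured pair shows a change of this kind, so nothing beyond the scatter is expected in this assay, starting from compound 2 at 22500 nM. The expected move is a 1.0-fold higher number from compound 2 to compound 4 (0.01 log units; within the scatter). Compound 4 is estimated at 23000 nM, with an expected range of 12000 nM to 38000 nM.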

Compound 4, half-maximal inhibitory concentration: 15600 nM
The estimate for compound 4 lay 1.5-fold (0.17 log units) above the measured number; measured number inside the range.
By their numbers in this assay, from the lowest: compounds 4, 2 and 1 (each within the scatter of the next). At a limit, above all of these: compound 3.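

Within the data shown here, putting sec-butyl in place of isobutyl on the amine nitrogen gives the first one-place comparison in this assay: a 1.4-fold lower number from compound 2 to compound 4 (0.16 log units; within the scatter). With the same atoms joined differently, the two chains cannot be told apart here, so this rearrangement of the butyl group makes no difference that stands clear of the scatter.

On these data alone, whether a methyl group or a longer chain on this nitrogen would give a clear difference stays open. The result for compound 3 is a limit, which marks where the scale ends: the limit of > 25000 nM in this assay, at which 1 of the 4 values shown sits.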